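A few compounds are considered here, and "the series" means these few. Any claim that something is new, unique, unknown or untested is made for them only; others in the source may bear on it.

Measured compounds in a functional assay on MDA-MB-231 cells (Homo sapiens) for antiproliferative activity, read by MTT assay, with a stated time of 72 h; on this read-out higher numbers stand for weaker inhibition and lower numbers for stronger inhibition:
compound 1 `CCn1nc(C#Cc2cc(C(=O)Nc3cccc(C(F)(F)F)c3)ccc2C)c2c(N)ncnc21` gives 360 nM
compound 2 `Cc1ccc(C(=O)Nc2cccc(C(F)(F)F)c2)cc1C#Cc1nn([C@@H]2CCN(C)C2)c2ncnc(N)c12` gives 13 nM

Among the measured compounds shown here, compound 2 holds the lower of these two numbers, and its only neighbour is compound 1; the gap between them, a 28-fold lower number from compound 1 to compound 2 (1.44 log units; beyond the scatter), came from a single change at one place on the shared core. Compound 3 `Cc1ccc(C(=O)Nc2cccc(C(F)(F)F)c2)cc1C#Cc1nn(CC2CCN(C)C2)c2ncnc(N)c12` has not yet been measured in this assay. It differs from compound 2 in just one place: (1-methylpyrrolidin-3-yl)methyl in place of 1-methylpyrrolidin-3-yl on an aromatic nitrogen. For the measured compounds named here, no measured step covers this exact change. Going by the values given here, the only step at this position, a 28-fold lower number from compound 1 to compound 2 (1.44 log units; beyond the scatter), shows that the group on that aromatic nitrogen can matter a great deal, but there a short chain was replaced by the ring, whereas here the same ring is kept and merely set one carbon further out. With the ring retained, a small to moderate step seems most likely, in either direction, with a slight lean towards a higher number. Compound 3 is therefore expected to give about 25 nM in this assay, within 8 nM to 80 nM. That estimate means a step of a 1.9-fold higher number from compound 2 to compound 3 (0.28 log units; within the scatter).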

Compound 3, half-maximal inhibitory concentration: 41 nM
The estimate for compound 3 lay 1.6-fold (0.21 log units) below the measured number; the measured number falls inside the stated range.
By their numbers in this assay, from the lowest: compound 2; then compound 3; then compound 1.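

In this assay, the exact placement of the ring on the aromatic nitrogen proves to matter: setting the same 1-methylpyrrolidine ring one carbon further out gives a 3.2-fold higher number from compound 2 to compound 3 (0.50 log units; beyond the scatter). The ring does not have to sit directly on that nitrogen to keep much of its advantage over the simple ethyl group, however, as an 8.8-fold lower number from compound 1 to compound 3 (0.94 log units; beyond the scatter) shows. Nothing available here explains why either step takes the size it does.

The step from compound 2 to compound 3 also joins two differences, since the group in compound 2 has a defined stereocentre and the group in compound 3 has none, so the effect of the added carbon cannot be separated from that of the undefined stereocentre. The compounds shown also leave open whether the ring itself is needed or whether its amine would do the same work elsewhere, as it might in an open dimethylaminoethyl chain, and how a six-membered 1-methylpiperidin-4-yl group would compare at this position.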